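Methyl in Place of Hydrogen on Two Related Cores

The source may report more compounds than this note shows. Statements on the series, on what has been measured and on what is new or still open speak of the compounds shown alone.

Three compounds have been tested in a functional assay on HeLa cells (Homo sapiens) for inhibition, read by MTT assay, with a stated time of 48 h; on this read-out higher numbers stand for weaker inhibition and lower numbers for stronger inhibition:

Compound 1, `CN1C(=O)CN(C2CCCC2)c2nc(Nc3ccc(N4CCCCC4)cc3)ncc21`, gives 16900 nM.
Compound 2, `CN1CCN(c2ccc(Nc3ncc4c(n3)N(C3CCCC3)CC(=O)N4C)nc2)CC1`, gives 13100 nM.
Compound 3, `CCN1C(=O)CN(C2CCCC2)c2nc(Nc3ccc(N4CCCCC4)cc3)ncc21`, reaches only the limit of the assay, > 30000 nM.

Compound 3 differs from compound 1 by methyl in place of hydrogen on a saturated chain carbon bound to an amide-type nitrogen in a ring, and this change gave an at least 1.7-fold higher number from compound 1 to compound 3 (0.24 log units; that floor lies within the scatter); the value of compound 3 is a limit, not a number (the limit of > 30000 nM in this assay, at which 1 of the 3 values shown sits). The difference between the cores of compound 1 and compound 2 is not broken down here; their two values lie within the scatter of each other.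

Compound 4, `CCN1C(=O)CN(C2CCCC2)c2nc(Nc3ccc(N4CCN(C)CC4)cn3)ncc21`, differs from compound 2 by methyl in place of hydrogen on a saturated chain carbon bound to an amide-type nitrogen in a ring, the same change. Because an at least 1.7-fold higher number from compound 1 to compound 3 (0.24 log units; that floor lies within the scatter) points toward a weaker number, the step from compound 2 to compound 4 is expected to be a 2.0-fold higher number from compound 2 to compound 4 (0.30 log units; within the scatter). Compound 4 is therefore estimated at 26000 nM, between 12000 nM and 60000 nM.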

Compound 4, half-maximal inhibitory concentration: 29100 nM
For compound 4 the middle estimate is 1.1-fold (0.05 log units) below the measured one, and the stated range covers the measured number.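

In this assay, methyl in place of hydrogen on the core of compound 2 gives a 2.2-fold higher number from compound 2 to compound 4 (0.35 log units; beyond the scatter), a modest weakening. Compound 3 gives > 30000 nM, which is a limit of the assay and not a number. The change can therefore be followed in size on only one of the two cores, so this pair does not show that the step carries over unchanged from one core to the other: the same change on two cores in this assay, an at least 1.7-fold higher number (0.24 log units; that floor lies within the scatter) from compound 1 to compound 3 and a 2.2-fold higher number (0.35 log units; beyond the scatter) from compound 2 to compound 4; the limit leaves it open whether they differ

The compounds shown leave open whether a longer chain, such as propyl, in the same place would raise the number further. They also leave open how a chain ending in an amine would behave on either core.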